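Replacing the sulfonamide arm of compound 2 with a difluorophenyl

This account rests on a few compounds, and the source may have more. Where it says the series, first, only, none or still open, it means among the compounds named here.

Measured compounds:
Compound 1 `CCCCc1cn(C[C@H](O)[C@H]2OC(=O)C(OCc3ccccc3)=C2OCc2ccccc2)nn1` gives 18100 nM in a functional assay on HeLa cells (Homo sapiens) for antiproliferative activity, read by MTT assay, with a stated time of 72 h; on this read-out higher numbers stand for weaker inhibition and lower numbers for stronger inhibition.
Compound 2 `O=C1O[C@H]([C@@H](O)Cn2cc(CNS(=O)(=O)c3ccc(Cl)cc3)nn2)C(OCc2ccccc2)=C1OCc1ccccc1` gives 13600 nM in this assay.

Going by the values given here, compound 2 holds the lower of the two numbers, but the only measured step, a 1.3-fold lower number from compound 1 to compound 2 (0.12 log units; within the scatter), is within the scatter, so the two compounds cannot be ranked against each other. Compound 3 `O=C1O[C@H]([C@@H](O)Cn2cc(-c3cc(F)cc(F)c3)nn2)C(OCc2ccccc2)=C1OCc1ccccc1` differs from compound 2 by 3,5-difluorophenyl in place of (((4-chlorophenyl)sulfonyl)amino)methyl on an aromatic carbon. Among the compounds with values here, the one step that bears on this change is the same exchange of the group on that aromatic carbon seen in a 1.3-fold lower number from compound 1 to compound 2 (0.12 log units; within the scatter), which hardly moved the number. On that basis no shift beyond the scatter is expected in this assay. Compound 3 is therefore estimated at 14000 nM, with a range from 5000 nM to 40000 nM. The expected step is a 1.0-fold higher number from compound 2 to compound 3 (0.01 log units; within the scatter).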

Compound 3, half-maximal inhibitory concentration: 40800 nM
For compound 3 the middle estimate is 2.9-fold (0.46 log units) below the measured one; the measured number lies above the stated range.
By their numbers in this assay, from the lowest: compounds 2 and 1 (each within the scatter of the next); then compound 3.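

In this assay, the group on this aromatic carbon of the five-membered ring with 3 nitrogen does affect the number, which the earlier pair could not show: 3,5-difluorophenyl gives a 3.0-fold higher number from compound 2 to compound 3 (0.48 log units; beyond the scatter) and a 2.3-fold higher number from compound 1 to compound 3 (0.35 log units; beyond the scatter), both modest but beyond the scatter. The number moves the same way against both butyl and (((4-chlorophenyl)sulfonyl)amino)methyl, two arms that could not be ranked against each other, so the rise is not tied to one particular departing group. Nothing available accounts for this shift.

The compounds shown leave open whether the rise belongs to the aromatic ring itself or to its two fluorines, a question that an unsubstituted phenyl would address. They also leave open whether any group here, such as an amine or a carboxylic acid, could lower the number beyond the scatter.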